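Propyl for nitrobenzyl on the sulfur of a weak inhibitor

The source may report more compounds than this note shows. Statements on the series, on what has been measured and on what is new or still open speak of the compounds shown alone.

Measured compounds:
compound 1, `Cc1cc(Nc2cc(-c3ccccc3)[nH]n2)n2nc(SCc3ccc([N+](=O)[O-])cc3)nc2n1`: 4250 nM
compound 2, `Cc1cc(Nc2ccn(Cc3ccccc3)n2)n2nc(SCc3ccc(Br)cc3)nc2n1`: 4720 nM

In a functional assay on MGC-803 cells (Homo sapiens) for inhibition, read by MTT assay, with a stated time of 72 h (a lower number here means a stronger inhibitor, a higher number a weaker inhibitor), compound 1 gives 4250 nM and compound 2 gives 4720 nM; the two numbers lie within the scatter of each other, so neither compound can be ranked above the other, and both sit in the weak range. Compound 3, `CCCSc1nc2nc(C)cc(Nc3cc(-c4ccccc4)[nH]n3)n2n1`, has not yet been measured in this assay. It differs from compound 1 in one place: ethyl in place of 4-nitrophenyl on a saturated chain carbon bound to a sulfur. Cut one bond further out, the (4-nitrobenzyl)sulfanyl group of compound 1 becomes propylsulfanyl. Among the measured compounds shown here, no step between two measured compounds shows what exchanging the group on the sulfur does here, since compounds 1 and 2 differ in more than one place. The expected step in this assay from compound 1 is a 1.5-fold higher number from compound 1 to compound 3 (0.18 log units; within the scatter), a modest weakening at most, not clearly beyond the scatter. Compound 3 is therefore estimated at 6500 nM, with a range from 2500 nM to 17000 nM.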

Compound 3, half-maximal inhibitory concentration: 12600 nM
Estimate against measurement, compound 3: 1.9-fold (0.29 log units) below; low and high end bracket the measured number.
By their numbers in this assay, from the lowest: compounds 1 and 2 (each within the scatter of the next); then compound 3.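

In this assay, among the compounds shown here, the first step that isolates the group on the sulfur is a 3.0-fold higher number from compound 1 to compound 3 (0.47 log units; beyond the scatter), with the rest of the molecule unchanged. This position therefore responds to the exchange: propylsulfanyl in place of (4-nitrobenzyl)sulfanyl, which removes the six-membered aromatic ring and the hydrogen-bond acceptors of the 4-nitrophenyl, goes with modestly weaker inhibition, starting from a compound that was already a weak inhibitor. No measurement at hand gives a reason for this step.

The compounds shown leave open which part of the 4-nitrobenzyl group matters, and whether an unsubstituted benzyl on the sulfur would read like compound 1 or like compound 3. They also leave open whether a longer chain such as hexyl, or a chain ending in an amine, would differ from propyl at this position.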